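The compounds below may be only part of what the source reports. "The series", "measured", "known", "first", "only" and "open" are said of these compounds alone.

Working notes on a small set of arylidene thiazolidinone analogues, all tested in a functional assay on HEp-2 cells (Homo sapiens) for cytotoxicity, read by MTT assay, with a stated time of 72 h, tested at 5 ug/mL; a higher number here means more inhibition of growth at the concentration tested, a lower number less inhibition of growth. Compound 1 `O=C1NC(=S)/C(=C/c2ccc(Cl)cc2)S1` gives 16.1% in this assay. Compound 2 `O=C1NC(=S)/C(=C/c2cc(Cl)cc(Cl)c2Cl)S1` gives 22.8% in this assay. Compound 3 `O=C1NC(=S)/C(=C/c2ccccc2Br)S1` gives 16.2% in this assay. On these three numbers compound 3 stands second highest; its nearest neighbour is compound 1, whose value lies within the scatter of it, and its furthest is compound 2, whose value also lies within the scatter of it. All three compounds therefore sit in a band that repeated measurements of this kind cannot separate.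

The next compound, compound 4 `O=C1NC(=S)/C(=C/c2ccccc2Cl)S1`, keeps the shared core of compound 3 and differs from it by a single exchange on the aromatic carbon: chloro in place of bromo on an aromatic carbon. Within the data shown here, no step between two measured compounds of this set isolates such an exchange, so nothing measured here tells how large an effect it should have. Given that the three measured compounds all fall within the scatter of one another, the expected step from compound 3 to compound 4 is a number 0.2 percentage points lower from compound 3 to compound 4 (within the scatter), that is, no change beyond the scatter in either direction. Compound 4 is accordingly expected to give 16% in this assay, with a range from 8% to 26%.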

Compound 4, percent growth inhibition at one concentration: 5.97%
Estimate against measurement, compound 4: 10 percentage points above; the whole stated range lies above it.
By their numbers in this assay, from the lowest: compound 4; then compounds 1, 3 and 2 (each within the scatter of the next).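

In this assay, among these compounds, the first step that can be read in this set is a number 10.2 percentage points lower from compound 3 to compound 4 (beyond the scatter), for chloro in place of bromo on an aromatic carbon, ortho to a group of 8 heavy atoms. This position therefore responds to the identity of the halogen: one heavy atom exchanged for another, with no change in rings, hydrogen-bond donors, hydrogen-bond acceptors or net charge, moves the read-out beyond the scatter, which the three earlier compounds, all within the scatter of one another, could not show. Nothing available accounts for this step.

From the compounds shown here alone, how a fluoro, a methyl, an amine or a carboxylic acid on this aromatic carbon would compare with bromo and chloro stays open. Also open, going by these compounds, is whether the same exchange on another aromatic carbon would give a step of similar size.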